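Removing the Carboxy Chain: From Compound 3 to Compound 4

This account rests on a few compounds, and the source may have more. Where it says the series, first, only, none or still open, it means among the compounds named here.

Compound 1 `CCCn1c(=O)n(C)c(=O)c2[nH]cnc21`: 1600 nM
Compound 2 `C=CCCn1cnc2c1c(=O)n(C)c(=O)n2CCC`: 16800 nM
Compound 3 `CCCn1c(=O)n(C)c(=O)c2c1ncn2CCC(=O)O`: > 100000 nM (a limit)

In a functional assay (trachea) with Cavia porcellus as the target (on this read-out lower numbers stand for an effect already at smaller amounts and higher numbers for an effect only at larger amounts of compound), compound 3 stands at a limit, > 100000 nM, and has no exact number. Compound 4 `CCCn1c(=O)n(C)c(=O)c2c1ncn2CC#N` differs from it by cyano in place of carboxymethyl on a saturated chain carbon bound to an aromatic nitrogen. For the measured compounds named here, two measured steps bear on this: an at least 5.9-fold higher number from compound 2 to compound 3 (0.77 log units; beyond the scatter), with carboxy in place of vinyl, and an 11-fold higher number from compound 1 to compound 2 (1.02 log units; beyond the scatter), with but-3-en-1-yl in place of hydrogen on an aromatic nitrogen. Compound 4 carries no carboxy, and neither does compound 2 at 16800 nM, so a step towards a lower number is expected. The expected change is an at least 8.3-fold lower number from compound 3 to compound 4 (0.92 log units; beyond the scatter). For compound 4 the estimate is 12000 nM, with an expected range from 3000 nM to 50000 nM.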

Compound 4, half-maximal effective concentration: 35300 nM
The estimate for compound 4 lay 2.9-fold (0.47 log units) below the measured number; the measured number falls inside the stated range.
By their numbers in this assay, from the lowest: compound 1; then compound 2; then compound 4. At a limit, above all of these: compound 3.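

In this assay, cyano in place of carboxymethyl on a saturated chain carbon bound to an aromatic nitrogen gives an at least 2.8-fold lower number from compound 3 to compound 4 (0.45 log units; beyond the scatter) and shows that this chain can return to a measurable number without carboxy. This step is read against a limit for compound 3: the limit of > 100000 nM in this assay, at which 1 of the 4 values shown sits. Cyano in place of allyl gives a 2.1-fold higher number from compound 2 to compound 4 (0.32 log units; beyond the scatter) and cyanomethyl in place of hydrogen gives a 22-fold higher number from compound 1 to compound 4 (1.34 log units; beyond the scatter) so all three groups on this nitrogen stay above compound 1, which carries hydrogen.

As far as these compounds go, it remains open whether an amine or a longer chain ending in a nitrile would come closer to compound 1.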